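Amide aryl replacements on the shared core: compound 4

The source may hold more compounds than are shown below. What is called first, only, known or untested is meant among the compounds shown, and "the series" means these compounds.

For the measured compounds named here, compound 3 `COc1ccc(-c2nc3c(C(=O)Nc4nc(C#N)c(C#N)[nH]4)cccc3[nH]2)cc1OC` gives 43.1 uM in an ADME assay on Vero cells (Chlorocebus sabaeus) for cytotoxicity (on this read-out higher numbers stand for lower toxicity in this test and lower numbers for higher toxicity in this test), the lowest of the three numbers so far. Compound 1 `COc1ccc(-c2nc3c(C(=O)Nc4cnc(Cl)cn4)cccc3[nH]2)cc1OC` gives 78.3 uM in this assay, and compound 2 `COc1ccc(-c2nc3c(C(=O)Nc4c[nH]cn4)cccc3[nH]2)cc1OC` gives 306 uM. Of the measured steps, a 1.8-fold lower number from compound 1 to compound 3 (0.26 log units; within the scatter), whereas a 7.1-fold lower number from compound 2 to compound 3 (0.85 log units; beyond the scatter) and a 3.9-fold higher number from compound 1 to compound 2 (0.59 log units; beyond the scatter). Compound 4 `COc1ccc(-c2nc3c(C(=O)Nc4ncccc4O)cccc3[nH]2)cc1OC` carries 3-hydroxypyridin-2-yl in place of 4,5-dicyano-1H-imidazol-2-yl on an amide-type nitrogen. Going by the values given here, no measured step covers a six-membered ring bearing a hydroxyl at this place, so the change is only loosely bracketed by the earlier replacements. Because the span between the two five-membered groups was a 7.1-fold lower number from compound 2 to compound 3 (0.85 log units; beyond the scatter), an upward move of that order or smaller is expected for compound 4. Compound 4 is therefore estimated at 85 uM, with a range from 30 uM to 250 uM. The expected step is a 2.0-fold higher number from compound 3 to compound 4 (0.29 log units; within the scatter).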

Compound 4, half-maximal toxic concentration: 164 uM
Estimate against measurement, compound 4: 1.9-fold (0.29 log units) below; the range from low to high includes it.
By their numbers in this assay, from the lowest: compounds 3 and 1 (each within the scatter of the next); then compounds 4 and 2 (each within the scatter of the next).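

In this assay, moving to 3-hydroxypyridin-2-yl on the amide-type nitrogen gives a 3.8-fold higher number from compound 3 to compound 4 (0.58 log units; beyond the scatter) and a 2.1-fold higher number from compound 1 to compound 4 (0.32 log units; beyond the scatter), while a 1.9-fold lower number from compound 2 to compound 4 (0.27 log units; within the scatter) keeps compound 4 level with compound 2. A high number at this place is therefore not confined to 1H-imidazol-4-yl, and a six-membered ring bearing a hydroxyl also reaches it. Nothing in the data gives a reason for these differences.

Still open, on these data alone, is what a pyridin-2-yl without the hydroxyl would give, or one carrying a methoxy or an amine instead, so the contribution of the hydroxyl cannot be separated from that of the ring.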